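The source may hold more compounds than are shown below. What is called first, only, known or untested is meant among the compounds shown, and "the series" means these compounds.

Measured so far in a functional assay on A549 cells (Homo sapiens) for antiproliferative activity, read by MTT assay, with a stated time of 24 h; a higher number here means a weaker inhibitor, a lower number a stronger inhibitor:
compound 1 `O=c1[nH]cc(S(=O)(=O)Nc2ccccc2-c2cn(-c3ccccc3)nn2)c(=O)[nH]1` gives 6790 nM
compound 2 `Cc1ccccc1-n1cc(-c2cccc(NS(=O)(=O)c3c[nH]c(=O)[nH]c3=O)c2)nn1` gives 5470 nM
compound 3 `Cc1cccc(-n2cc(-c3cccc(NS(=O)(=O)c4c[nH]c(=O)[nH]c4=O)c3)nn2)c1` gives 3550 nM

Compound 3 has the lowest of the three numbers in this assay, but the spread is small. Going by the values given here, the only change between measured compounds that touches one place is a 1.5-fold lower number from compound 2 to compound 3 (0.19 log units; within the scatter), a swap of 2-methylphenyl for 3-methylphenyl on the aromatic nitrogen of the shared core, and it stays within the usual scatter. Compound 3 differs in more than one place from compound 1, whose number is 6790 nM, so the two can only be set beside each other; they are also within scatter of each other, so no ordering can be read from them.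

Compound 4 `O=c1[nH]cc(S(=O)(=O)Nc2cccc(-c3cn(-c4ccc(F)cc4)nn3)c2)c(=O)[nH]1` differs from compound 3 in one place: 4-fluorophenyl in place of 3-methylphenyl on an aromatic nitrogen. Among the compounds with values here, whether a different group on this aromatic nitrogen shifts the number is not known from these data beyond the one swap already described, and that swap was within scatter. The expectation is therefore a step no larger than the scatter, a 1.1-fold higher number from compound 3 to compound 4 (0.05 log units; within the scatter). For compound 4 the estimate in this assay is 4000 nM, with a range from 1800 nM to 9000 nM.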

Compound 4, half-maximal inhibitory concentration: > 20000 nM
Compound 4 was reported as a limit; the forecaster's own chance of this, stated with the estimate: 5%; at least 5.0-fold (0.69 log units) between middle value and limit.
By their numbers in this assay, from the lowest: compounds 3, 2 and 1 (each within the scatter of the next). At a limit, above all of these: compound 4.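

In this assay compound 4 is reported only as a limit, not as a number, and the finding rests on this single compound: the limit of > 20000 nM in this assay, at which 1 of the 4 values shown sits.

Even so, the group on this aromatic nitrogen now makes a difference larger than the scatter: 4-fluorophenyl in place of 3-methylphenyl gives an at least 5.6-fold higher number from compound 3 to compound 4 (0.75 log units; beyond the scatter), and 4-fluorophenyl in place of 2-methylphenyl gives an at least 3.6-fold higher number from compound 2 to compound 4 (0.56 log units; beyond the scatter). Going by these compounds alone, the earlier swap between the two methylphenyl groups gave no step beyond the scatter, so this is the first sign that the number responds to a change here, even though the groups that leave and enter have the same count of heavy atoms and neither has hydrogen-bond donors or acceptors.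

The compounds shown cannot tell whether the fluorine itself or the place of the substituent on the phenyl ring accounts for the step, as both differ at once between compound 3 and compound 4; 3-fluorophenyl and 4-methylphenyl on the same nitrogen would separate the two. From the compounds shown here alone, how an amine or a carboxylic acid on that phenyl ring would read in this assay also stays open.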